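The source may report more compounds than this note shows. Statements on the series, on what has been measured and on what is new or still open speak of the compounds shown alone.

Of the compounds shown here, two have been measured in a functional assay on SK-OV-3 cells (Homo sapiens) for cytotoxicity; a higher number here means a weaker inhibitor of growth, a lower number a stronger inhibitor of growth. Compound 1 `COc1ccc(C2=C(c3ccc(SC)cc3)CC3CCCN3C2=O)cc1OC(=O)C1CCCN1C(=O)OC(C)(C)C` gives 10000 nM there. Compound 2 `CSc1ccc(C2=C(c3ccc(F)c(F)c3)C(=O)N3CCCC3C2)cc1` gives 100 nM in this assay, the lowest of the two numbers, and its gap to compound 1 lies beyond the scatter. Compound 3 `CSc1ccc(C2=C(c3ccc(SC)cc3)C(=O)N3CCCC3C2)cc1` differs from compound 2 in one place: 4-(methylsulfanyl)phenyl in place of 3,4-difluorophenyl on a double-bonded ring carbon. Since the group that leaves and the group that enters are each one six-membered aromatic ring of carbon only, a small step is expected, with no firm direction, namely a 1.5-fold higher number from compound 2 to compound 3 (0.18 log units; within the scatter). Compound 3 is therefore expected to give about 150 nM, most likely between 40 nM and 600 nM.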

Compound 3, concentration for 50% growth inhibition: 2000 nM
The estimate for compound 3 lay 13-fold (1.12 log units) below the measured number, outside the stated range (above it).
By their numbers in this assay, from the lowest: compound 2; then compound 3; then compound 1.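

In this assay the double-bonded ring carbon proves sensitive to what its ring carries: 4-(methylsulfanyl)phenyl in place of 3,4-difluorophenyl gives a 20-fold higher number from compound 2 to compound 3 (1.30 log units; beyond the scatter) even though each group is one six-membered aromatic ring of carbon only. So having an aromatic ring at this position does not by itself set the number; what that ring carries matters as well. No measurement shown gives a reason for this step. Going by these compounds, it remains open whether the fluorines of compound 2 or the methylsulfanyl group of compound 3 drives the gap. On these data alone, how a phenyl ring bearing an amine or a carboxylic acid would behave here is also open.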